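Cyclic sulfonate series: ether substituent and tolerated concentration

The compounds below may be only part of what the source reports. "The series", "measured", "known", "first", "only" and "open" are said of these compounds alone.

Measured compounds and values:
- Compound 1 `CCC1(Cc2ccccc2)OS(=O)(=O)C=C1OCCCCc1ccccc1`: 99000 nM
- Compound 2 `CCC1(Cc2ccccc2)OS(=O)(=O)C=C1OC`: > 200000 nM
- Compound 3 `CCC1(Cc2ccccc2)OS(=O)(=O)C=C1OCc1ccc(OC)cc1`: > 200000 nM

In an ADME assay on HEL cells (Homo sapiens) for cytotoxicity, with a stated time of 3 days (a higher number here means that more compound is tolerated, a lower number that less compound is tolerated), compound 1 gives 99000 nM. Compound 2 reaches only the limit of this assay, > 200000 nM. Compound 3 likewise sits at the limit, > 200000 nM, so its position on the numbers is known only as a floor; it is one of the two values at the limit (the limit of > 200000 nM in this assay, at which 2 of the 3 values shown sit). Compound 4 `CCC1(Cc2ccccc2)OS(=O)(=O)C=C1OCc1ccccc1Cl` is not yet measured. It differs from compound 3 in one place (2-chlorophenyl in place of 4-methoxyphenyl on a saturated chain carbon bound to an oxygen on an unsaturated carbon).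

For the measured compounds named here, the steps that bear on this position are an at least 2.0-fold higher number from compound 1 to compound 2 (0.30 log units; that floor lies within the scatter) and an at least 2.0-fold higher number from compound 1 to compound 3 (0.30 log units; that floor lies within the scatter); both replace the 3-phenylpropyl group and both end at the limit. The step that the two limits leave unreadable from compound 2 to compound 3 cannot be read, since both ends are limits. Going by the values given here, no measured step has exchanged one aryl group for another at this carbon, so the 2-chlorophenyl change has no direct precedent here; the nearest evidence is that a methoxyphenyl at this place does not lower the tolerated concentration below the limit.

Compound 4 is therefore expected to remain near or at the limit, with no step beyond the scatter in this assay: the expected step is a number no higher from compound 3 to compound 4 (the limit leaves the size open). The estimate for compound 4 is 200000 nM, with a range from 90000 nM to 400000 nM.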

Compound 4, half-maximal cytotoxic concentration: 38000 nM
The estimate for compound 4 lay 5.3-fold (0.72 log units) above the measured number, and the stated range ends above it.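

In this assay, exchanging 4-methoxyphenyl for 2-chlorophenyl on a saturated chain carbon bound to an oxygen on an unsaturated carbon gives an at least 5.2-fold lower number from compound 3 to compound 4 (0.72 log units; beyond the scatter), the first readable sign that the choice of aryl group at this place matters. Replacing hydrogen with 2-chlorophenyl gives an at least 5.2-fold lower number from compound 2 to compound 4 (0.72 log units; beyond the scatter), and these two sizes are only floors because compounds 2 and 3 both sit at a limit: the limit of > 200000 nM in this assay, at which 2 of the 4 values shown sit. For the compounds shown here, replacing 3-phenylpropyl with 2-chlorophenyl gives a 2.6-fold lower number from compound 1 to compound 4 (0.42 log units; beyond the scatter), the only one of the three steps with a full size, so a lower tolerated concentration in this set is not confined to the 3-phenylpropyl group.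

The step from compound 2 to compound 3 still cannot be read, since both of its ends are limits, so hydrogen and 4-methoxyphenyl remain unordered at this place. The compounds shown do not separate the gain of the chlorine from the loss of the methoxy group, and an unsubstituted phenyl or a pyridyl group at this carbon would bear directly on that question.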